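From Ring Ketone to Ring Hydroxyl on the Chain

The source may hold more compounds than are shown below. What is called first, only, known or untested is meant among the compounds shown, and "the series" means these compounds.

Of the compounds shown here, three sharing one core have been measured in an assay on cerebellum for displacement of a labelled ligand from histamine H1 receptor (Cavia porcellus), read by scintillation counting, with a stated time of 60 min; a lower number here means a stronger inhibitor, a higher number a weaker inhibitor. Compound 1 `CN1CCc2ccc(OCCCN3CCCCC3)cc2C1=O` gives 23 nM. Compound 2 `CCN1CCN(CCCOc2ccc3c(c2)C(=O)N(C)CC3)CC1` gives 1100 nM, and compound 3 `CN1CCc2ccc(OCCCN3CCC(=O)CC3)cc2C1=O` gives 176 nM, which places compound 3 second highest of the three numbers. The step to be made is 3-hydroxypyrrolidin-1-yl in place of 4-oxopiperidin-1-yl on a saturated chain carbon, three bonds along the chain from an oxygen on an aromatic ring, giving compound 4 `CN1CCc2ccc(OCCCN3CCC(O)C3)cc2C1=O`. Going by the values given here, two measured steps bear on it, since both change the ring on that saturated chain carbon: a 7.7-fold higher number from compound 1 to compound 3 (0.88 log units; beyond the scatter) and a 48-fold higher number from compound 1 to compound 2 (1.68 log units; beyond the scatter). On these data alone, each such change moved the number beyond the scatter, so a shift is expected here too, though a hydroxyl on a five-membered ring is untested. The expected step is a 1.5-fold lower number from compound 3 to compound 4 (0.17 log units; within the scatter). For compound 4 the estimate is 120 nM, with a range from 30 nM to 500 nM.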

Compound 4, inhibition constant: 112 nM
Compound 4: middle estimate off by 1.1-fold (0.03 log units), on the high side; the measured number falls inside the stated range.
By their numbers in this assay, from the lowest: compound 1; then compounds 4 and 3 (each within the scatter of the next); then compound 2.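

Replacing 4-oxopiperidin-1-yl with 3-hydroxypyrrolidin-1-yl changes the ring size and the oxygen group together and adds a hydrogen-bond donor, yet it gives a 1.6-fold lower number from compound 3 to compound 4 (0.20 log units; within the scatter) and so leaves no readable difference. Both oxygen-bearing rings sit in the same middle band, with a 4.9-fold higher number from compound 1 to compound 4 (0.69 log units; beyond the scatter) and a 9.8-fold lower number from compound 2 to compound 4 (0.99 log units; beyond the scatter) on either side. Nothing measured here explains these differences. On these data alone, what the ring size and the hydroxyl each contribute alone stays open: pyrrolidin-1-yl or 4-hydroxypiperidin-1-yl on the same chain carbon would separate them.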